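Fluoro in place of methoxy on compound 2

The source may hold more compounds than are shown below. What is called first, only, known or untested is meant among the compounds shown, and "the series" means these compounds.

Compound 1 `COc1ccc(C(=O)CCN2CCN(c3ccc(Cl)cc3)CC2)cc1` gives 300000 nM
Compound 2 `COc1ccccc1N1CCN(CCC(=O)c2ccc(F)cc2)CC1` gives 24000 nM

In an ADME assay on Vero cells (Chlorocebus sabaeus) for cytotoxicity, read by resazurin assay, with a stated time of 72 h (a higher number here means a weaker inhibitor, a lower number a stronger inhibitor), compound 2 holds the lower of the two numbers, at 24000 nM, and its gap to compound 1 lies beyond the scatter. Compound 3 `O=C(CCN1CCN(c2ccccc2F)CC1)c1ccc(F)cc1` differs from compound 2 by fluoro in place of methoxy on an aromatic carbon, with fluoro in place of methoxy on an aromatic carbon, ortho to a large group. For the measured compounds named here, no measured pair shows this change, so only the two values serve as a guide. The expected change a 1.9-fold higher number from compound 2 to compound 3 (0.27 log units; within the scatter) is a small step toward a higher number, not clearly beyond the scatter. The estimated value for compound 3 is 45000 nM in this assay, with an expected range from 15000 nM to 150000 nM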

Compound 3, half-maximal inhibitory concentration: 49500 nM
Beside the measured number, compound 3's estimate is 1.1-fold (0.04 log units) below it, within the range that was stated.
By their numbers in this assay, from the lowest: compound 2; then compound 3; then compound 1.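

In this assay, for the compounds shown here, replacing methoxy with fluoro gives a 2.1-fold higher number from compound 2 to compound 3 (0.31 log units; beyond the scatter), the only comparison here in which just one place changes. It shows that this aromatic carbon, ortho to a large group, is not silent to the change: the step is modest but lies beyond the scatter. Nothing available explains the step. The compounds shown leave open whether an amine or a nitrile on this same carbon would shift the number further. They also leave open whether fluoro in place of methoxy would give a similar step elsewhere on that ring.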